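Aryloxy carbamate series: chloro addition toward zeta-carotene desaturase

The compounds below may be only part of what the source reports. "The series", "measured", "known", "first", "only" and "open" are said of these compounds alone.

compound 1 `CCC(COc1cccc(C(F)(F)F)c1)OC(=O)NCc1ccccc1`: > 100000 nM
compound 2 `CCC(COc1ccc(Cl)cc1)OC(=O)NCc1ccccc1`: > 100000 nM
compound 3 `CCC(COc1c(Cl)cccc1Cl)OC(=O)NCc1ccccc1`: > 100000 nM

In an assay for inhibition of zeta-carotene desaturase, chloroplastic/chromoplastic (Capsicum annuum), using a Dixon plot, with a stated time of 8 h (on this read-out lower numbers stand for stronger inhibition and higher numbers for weaker inhibition), compound 2 is recorded only as a limit, not a number. The same holds for compound 1 and compound 3; all three sit at the limit of > 100000 nM in this assay, at which 3 of the 3 values shown sit. Among the measured compounds shown here, the single one-place step measured so far, a step that the two limits leave unreadable from compound 2 to compound 3, is therefore unreadable in size and direction.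

Compound 4 `CCC(COc1ccc(Cl)c(Cl)c1)OC(=O)NCc1ccccc1` carries chloro in place of hydrogen on an aromatic carbon. No measured step bears readably on this change, and the values shown give no reason to expect compound 4 to leave the limit. Compound 4 is expected to return a limit in this assay as well, with an estimated value of 200000 nM (range 50000 nM to 1000000 nM); the expected step is a step that the limit leaves unreadable from compound 2 to compound 4.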

Compound 4, half-maximal inhibitory concentration: > 100000 nM
Compound 4: only a limit was reported; the forecaster's own chance of this, stated with the estimate: 85%; the middle value is on the limit's open side.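

Compound 4 is likewise recorded only as a limit, so the steps to compound 4 from compound 2 and compound 3 cannot be read: the limit of > 100000 nM in this assay, at which 4 of the 4 values shown sit.

The compounds shown leave open whether any change to the shared core gives a measurable value in this assay.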